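Swapping a Trifluoromethylphenyl for a Methoxyphenyl Group

The compounds below may be only part of what the source reports. "The series", "measured", "known", "first", "only" and "open" are said of these compounds alone.

Of the compounds shown here, two built on one shared core have been measured in a functional assay on HT-29 cells (Homo sapiens) for antiproliferative activity, read by MTT assay, with a stated time of 48 h; a lower number here means a stronger inhibitor of growth, a higher number a weaker inhibitor of growth. Compound 1 `S=C(Nc1ccccc1)N1N=C(c2ccccc2)CC1c1ccc2c(c1)OCCO2` carries a plain phenyl group and gives 6630 nM. For the measured compounds named here, compound 2 `FC(F)(F)c1ccc(C2=NN(C(=S)Nc3ccccc3)C(c3ccc4c(c3)OCCO4)C2)cc1` carries a 4-(trifluoromethyl)phenyl group in its place and gives 97500 nM, the highest number of the two; the single measured step, a 15-fold higher number from compound 1 to compound 2 (1.17 log units; beyond the scatter), shows that adding trifluoromethyl to that phenyl left a much weaker inhibitor.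

Compound 3 `COc1cccc(C2=NN(C(=S)Nc3ccccc3)C(c3ccc4c(c3)OCCO4)C2)c1` is the next compound. It differs from compound 2 as follows: 3-methoxyphenyl in place of 4-(trifluoromethyl)phenyl on a carbon with a double bond to nitrogen. Going by the values given here, no measured step shows what a methoxy group does at this position, so the only step that bears on the change is the one from compound 1 to compound 2, and it was large. Going by these compounds, the trifluoromethyl that accompanied a 15-fold higher number from compound 1 to compound 2 (1.17 log units; beyond the scatter) is removed, so a lower number than that of compound 2 is expected, though the methoxy group it gains is untested and the range is kept wide. Compound 3 is therefore estimated to give about 15000 nM, between 4000 nM and 60000 nM, an expected step of a 6.5-fold lower number from compound 2 to compound 3 (0.81 log units; beyond the scatter).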

Compound 3, concentration for 50% growth inhibition: 2920 nM
For compound 3 the middle estimate is 5.1-fold (0.71 log units) above the measured one; the measured number lies below the stated range.
By their numbers in this assay, from the lowest: compound 3; then compound 1; then compound 2.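

In this assay a group added to this phenyl need not leave a weaker inhibitor: 3-methoxyphenyl in place of plain phenyl gives a 2.3-fold lower number from compound 1 to compound 3 (0.36 log units; beyond the scatter) and so moves the number the opposite way from trifluoromethyl. The direct swap of 4-(trifluoromethyl)phenyl for 3-methoxyphenyl gives a 33-fold lower number from compound 2 to compound 3 (1.52 log units; beyond the scatter) and is much larger than that modest step, so most of it reflects leaving behind the high number of compound 2 rather than any gain over plain phenyl. Nothing at hand explains why these two groups move the number in opposite directions.

Trifluoromethyl and methoxy each appear at only one place on the phenyl in the compounds shown, so the identity of the group and its place on that ring cannot yet be told apart. Going by these compounds, it also remains open whether an amine, a carboxylic acid or a longer chain such as ethoxy on this phenyl would follow methoxy toward a lower number or trifluoromethyl toward a higher one.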